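Iodo for 3-nitrophenyl: cytotoxicity on two cores

This account rests on a few compounds, and the source may have more. Where it says the series, first, only, none or still open, it means among the compounds named here.

Measured so far:
compound 1, `Cc1cc(-c2cccc([N+](=O)[O-])c2)c2ncc(CSCCc3ccccc3)n2c1`: in an ADME assay on HEL cells (Homo sapiens) for cytotoxicity, with a stated time of 3 days (on this read-out higher numbers stand for lower toxicity in this test and lower numbers for higher toxicity in this test), compound 1 gives 47 ug/mL.
compound 2, `Cc1cc(I)c2ncc(CSCCc3ccccc3)n2c1`: compound 2 reaches only a limit of this assay, > 50 ug/mL.
compound 3, `Cc1cc(-c2cccc([N+](=O)[O-])c2)cn2c(CSCCc3ccccc3)cnc12`: in this assay compound 3 gives 43 ug/mL.

The change iodo in place of 3-nitrophenyl on an aromatic carbon gives an at least 1.0-fold higher number from compound 1 to compound 2 (0.02 log units; that floor lies within the scatter), bounded by the limit of > 50 ug/mL in this assay, at which 1 of the 3 values shown sits. Compound 3 is built on a core differing from that of compound 1; the difference between the two cores is not broken down here. Compound 4, `Cc1cc(I)cn2c(CSCCc3ccccc3)cnc12`, is unmeasured and arises from compound 3 by iodo in place of 3-nitrophenyl on an aromatic carbon, the same kind of change: the place is ortho to a fused ring in compound 1, para to a fused ring in compound 3. In this assay compound 4 is expected at 48 ug/mL, a step of a 1.1-fold higher number from compound 3 to compound 4 (0.05 log units; within the scatter), resting on the step of an at least 1.0-fold higher number from compound 1 to compound 2 (0.02 log units; that floor lies within the scatter) and on the value of compound 3, 43 ug/mL.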

Compound 4, half-maximal cytotoxic concentration: > 50 ug/mL
Compound 4 ended at the assay's limit; the forecaster's own chance of this, stated with the estimate: 40%; middle value at least 1.0-fold (0.01 log units) from the limit.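

In this assay, iodo in place of 3-nitrophenyl on the second core gives an at least 1.1-fold higher number from compound 3 to compound 4 (0.06 log units; that floor lies within the scatter). Compound 4 gives > 50 ug/mL, which is a limit of the assay and not a number: the limit of > 50 ug/mL in this assay, at which 2 of the 4 values shown sit. Carrying the change from one core to the other thus yields a floor on each core and no readable gap, but it does not show that the two cores respond alike: the same change on two cores in this assay, an at least 1.0-fold higher number (0.02 log units; that floor lies within the scatter) from compound 1 to compound 2 and an at least 1.1-fold higher number (0.06 log units; that floor lies within the scatter) from compound 3 to compound 4; the limit leaves it open whether they differ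

Going by these compounds, the true values of compound 2 and compound 4 remain open. Also open, on these data alone, is whether an amine or a carboxylic acid in the same place would give the same picture on both cores.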